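The compounds below may be only part of what the source reports. "The series", "measured", "known", "first", "only" and "open" are said of these compounds alone.

Measured compounds:
Compound 1 `CC(C(=O)N1CCN(c2ccccc2)CC1)N1C(=O)CCC1=O`: 0%
Compound 2 `CC(C(=O)N1CCN(c2ccc(Cl)cc2)CC1)N1C(=O)CCC1=O`: 0%
Compound 3 `CC(C(=O)N1CCN(c2ccccc2F)CC1)N1C(=O)CCC1=O`: 0%

Of the compounds shown here, three sharing one core have been tested in a functional assay on the whole organism (strain Swiss) with Mus musculus as the target, in the maximal electroshock model, with a stated time of 2 h, at a dose of 100 mg/kg by the intraperitoneal route; a lower number here means a weaker effect, a higher number a stronger effect of the compound at the dose given. Compound 1 `CC(C(=O)N1CCN(c2ccccc2)CC1)N1C(=O)CCC1=O` gives 0%, compound 2 gives 0% and compound 3 gives 0%, so compound 3 stands level with compounds 1 and 2, with nothing to separate any of them. The steps bear this out: no change at the digits printed from compound 1 to compound 2 (within the scatter), no change at the digits printed from compound 1 to compound 3 (within the scatter) and no change at the digits printed from compound 2 to compound 3 (within the scatter).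

Compound 4 `CC(C(=O)N1CCN(c2cccc(F)c2)CC1)N1C(=O)CCC1=O` is the next compound, and it differs from compound 3 as follows: 3-fluorophenyl in place of 2-fluorophenyl on an amine nitrogen in a ring. All three measured steps alter the aryl group on the ring nitrogen, and none of them moves the read-out beyond the scatter, so the same kind of change in compound 4 gives no reason to expect a step of any size in this assay. The expected step is no change at the digits printed from compound 3 to compound 4 (within the scatter), that is, none beyond the scatter. Compound 4 is therefore estimated at 0%, with a range from 0% to 10%.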

Compound 4, a percentage reported as activity, at one dose (the size of the read-out at that dose, not a potency): 0%
Estimate against measurement, compound 4: no gap at the digits printed; measured number inside the range.
By their numbers in this assay, from the lowest: compounds 1, 2, 3 and 4 (each within the scatter of the next).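

In this assay, 3-fluorophenyl in place of 2-fluorophenyl on the amine nitrogen in a ring gives no change at the digits printed from compound 3 to compound 4 (within the scatter), so a change in where the fluoro sits on the phenyl, with the same atoms, leaves the read-out where it was. The comparisons with the other aryl groups agree, with no change at the digits printed from compound 2 to compound 4 (within the scatter) and no change at the digits printed from compound 1 to compound 4 (within the scatter), so none of the four aryl groups on this nitrogen can be ranked above another. Nothing available explains this absence of effect.

The compounds leave open whether a different group on this nitrogen, such as trifluoromethylphenyl, benzyl or pyridyl, would give any reading in this assay at all. On these data alone, it is also open whether replacing the methyl on the shared core with a longer chain would do so.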